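This account rests on a few compounds, and the source may have more. Where it says the series, first, only, none or still open, it means among the compounds named here.

Working notes on the series in an ADME assay on Vero cells (Chlorocebus sabaeus) for inhibition, read by sulforhodamine B assay, with a stated time of 48 h; on this read-out higher numbers stand for weaker inhibition of growth and lower numbers for stronger inhibition of growth.

Compound 2 `CC1=CC[C@H](C(C)(C)NC(=S)N/N=C/c2ccc[nH]2)CC1` stands at a limit of the assay rather than at a number: in this assay compound 2 gives > 100000 nM. Among the measured compounds shown here, its only neighbour with a measurement is compound 1 `CC1=CC[C@H](C(C)(C)NC(=S)N/N=C/c2ccccc2Cl)CC1`, which in this assay also sits at a limit, giving > 100000 nM. The step that the two limits leave unreadable from compound 1 to compound 2 therefore cannot be read in either direction; both values sit at the limit of > 100000 nM in this assay, at which 2 of the 2 values shown sit, and nothing shown resolves a step between them.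

The next compound, compound 3 `CC1=CC[C@H](C(C)(C)NC(=S)N/N=C/c2cccs2)CC1`, differs from compound 2 by thiophen-2-yl in place of 1H-pyrrol-2-yl on a carbon with a double bond to nitrogen. For the measured compounds named here, no measured step bears on this exchange; the one measured step is unreadable, and both measured compounds show no total growth inhibition within the tested range of this assay. On that basis no change beyond the scatter is expected, and the most likely outcome for compound 3 is again a limit rather than a number.

Compound 3 is expected to give 150000 nM in this assay, within 50000 nM to 500000 nM, which corresponds to an expected step that the limit leaves unreadable from compound 2 to compound 3.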

Compound 3, concentration for total growth inhibition: 13400 nM
Compound 3: the middle estimate sits 11-fold (1.05 log units) above what was measured, outside the stated range (below it).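

In this assay, among the compounds shown here, compound 3 is the first compound to give a number rather than a limit, which shows that the group on a carbon with a double bond to nitrogen can move this read-out on the shared core. Thiophen-2-yl in place of 1H-pyrrol-2-yl gives an at least 7.4-fold lower number from compound 2 to compound 3 (0.87 log units; beyond the scatter), and thiophen-2-yl in place of 2-chlorophenyl gives an at least 7.4-fold lower number from compound 1 to compound 3 (0.87 log units; beyond the scatter), so the same group brings stronger inhibition of growth against both a five-membered and a chlorinated six-membered neighbour. Both steps are minimum sizes only, because each starts from a compound at a limit, and the number for compound 3 stands alone in the series: the limit of > 100000 nM in this assay, at which 2 of the 3 values shown sit.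

From the compounds shown here alone, the full size of either step stays open, with compound 1 and compound 2 known only as limits. Also open, going by these compounds, is whether the change follows the ring sulfur or the loss of the ring hydrogen-bond donor, and whether furan-2-yl, with oxygen in the ring, or an unsubstituted phenyl at this place would also give a number.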